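Replacing the ethyl on the ring nitrogen of compound 2

This account rests on a few compounds, and the source may have more. Where it says the series, first, only, none or still open, it means among the compounds named here.

Of the compounds shown here, two have been measured in a functional assay on LNCaP cells (Homo sapiens) for cytotoxicity; on this read-out higher numbers stand for weaker inhibition and lower numbers for stronger inhibition. Compound 1, `CNC(=O)Nc1ccc(-c2nc(N3CC4CCC(C3)O4)c3cnn(C(C)C)c3n2)cc1`, gives 5 nM in this assay. For the measured compounds named here, compound 2, `CCn1ncc2c(N3CC4CCC(C3)O4)nc(-c3ccc(NC(=O)NC)cc3)nc21`, gives 70 nM in this assay and so stands highest of the two numbers; its only neighbour is compound 1, and the step of a 14-fold higher number from compound 1 to compound 2 (1.15 log units; beyond the scatter) is a hydrogen in place of methyl on a saturated chain carbon bound to an aromatic nitrogen and a saturated chain carbon.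

Compound 3, `CNC(=O)Nc1ccc(-c2nc(N3CC4CCC(C3)O4)c3cnn(C4CCC(OC)(OC)CC4)c3n2)cc1`, has not yet been measured in this assay. It differs from compound 2 as follows: a group of 10 heavy atoms (8 carbon, 2 oxygen; one six-membered non-aromatic ring of carbon only) in place of a group of 2 heavy atoms (2 carbon; no ring), on an aromatic nitrogen. Going by the values given here, the one measured step bears on this change only loosely, since it concerns the same aromatic nitrogen but goes in the direction of fewer atoms, and it was large. Among the compounds with values here, no measured pair shows the entering group itself. He therefore expects compound 3 to give a lower number than compound 2, with the step of a 4.7-fold lower number from compound 2 to compound 3 (0.67 log units; beyond the scatter), while allowing a wide range. His estimate for compound 3 in this assay is 15 nM, between 3 nM and 80 nM.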

Compound 3, half-maximal inhibitory concentration: 2 nM
Beside the measured number, compound 3's estimate is 7.5-fold (0.88 log units) above it; the whole stated range lies above it.
By their numbers in this assay, from the lowest: compound 3; then compound 1; then compound 2.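

In this assay, the aromatic nitrogen of the shared core proved able to carry far more than a short chain: the change from ethyl to the group of 10 heavy atoms, with its six-membered carbon ring and two oxygen atoms, gave a 35-fold lower number from compound 2 to compound 3 (1.54 log units; beyond the scatter) and did not cost activity. The earlier pair covered only the two small chains, so it could not show whether the trend toward lower numbers with a larger group stopped at the chain of compound 1; a 2.5-fold lower number from compound 1 to compound 3 (0.40 log units; beyond the scatter) shows that it continues, though this last step is much smaller than the one from ethyl, and none of the three compounds goes against the order. Nothing measured here explains why the larger group gives the lower number.

The compounds shown leave open whether the carbon ring alone accounts for the step or the two methoxy groups on it also contribute, since a plain cyclohexyl group does not stand among them. From the compounds shown here alone, how a ketone, a hydroxyl or an amine at that ring carbon would read in this assay also remains open.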